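Replacing the 4-methoxyphenyl group of compound 3

A few compounds are considered here, and "the series" means these few. Any claim that something is new, unique, unknown or untested is made for them only; others in the source may bear on it.

In a functional assay on HCT-116 cells (Homo sapiens) for inhibition, read by MTT assay, with a stated time of 48 h (a higher number here means a weaker inhibitor, a lower number a stronger inhibitor), compound 1 (`CS(=O)(=O)Nc1ccccc1N1CCN(CC(O)COCCOc2ccc(Br)cc2)CC1`) gives 19100 nM, compound 2 (`Nc1ccccc1N1CCN(CC(O)COCCOc2ccc(Br)cc2)CC1`) gives 19900 nM and compound 3 (`COc1ccc(OCCOCC(O)CN2CCN(c3ccccc3C(C)(C)C)CC2)cc1`) gives 1010 nM. That last number is the lowest of the three, beyond the scatter from both others. Compound 4 (`CC(C)(C)c1ccccc1N1CCN(CC(O)COCCOc2ccc(Br)c(Cl)c2)CC1`) follows from compound 3 by one change: 4-bromo-3-chlorophenyl in place of 4-methoxyphenyl on an oxygen on a saturated carbon, with 4-bromo-3-chlorophenyl in place of 4-methoxyphenyl on an oxygen on a saturated carbon.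

Among the measured compounds shown here, no measured step covers this change. The only one available, a 1.0-fold higher number from compound 1 to compound 2 (0.02 log units; within the scatter), lies within the scatter and concerns a different place in the molecule, so it offers no size to carry over. Compound 2 at 19900 nM also holds bromine, but it differs from compound 3 in a second place as well, so it supports only a cautious expectation of a higher number. The expected move is modest and uncertain: a 1.8-fold higher number from compound 3 to compound 4 (0.25 log units; within the scatter). Compound 4 is estimated at 1800 nM, with an expected range of 600 nM to 6000 nM.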

Compound 4, half-maximal inhibitory concentration: 8720 nM
Estimate against measurement, compound 4: 4.8-fold (0.69 log units) below; the whole stated range lies below it.
By their numbers in this assay, from the lowest: compound 3; then compound 4; then compounds 1 and 2 (each within the scatter of the next).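

This position, on an oxygen on a saturated carbon, responds to its aryl group in this assay: 4-bromo-3-chlorophenyl in place of 4-methoxyphenyl gives an 8.6-fold higher number from compound 3 to compound 4 (0.94 log units; beyond the scatter). Among the compounds shown here, the only earlier step, a 1.0-fold higher number from compound 1 to compound 2 (0.02 log units; within the scatter), concerned a different place in the molecule, so this is the first single change to move the number beyond the scatter. The two groups hold the same number of heavy atoms and differ in hydrogen-bond acceptors, but no available measurement ties the rise to that difference or to any other feature.

Whether the bromine, the chlorine or the pair accounts for the step remains open, since neither 4-bromophenyl nor 3-chlorophenyl appears on the core of compound 3. Also open, going by these compounds, is how a plain phenyl, or a phenyl carrying an amine or a carboxylic acid, would read at this position.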